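The source may hold more compounds than are shown below. What is called first, only, known or untested is meant among the compounds shown, and "the series" means these compounds.

Measured compounds:
compound 1 `ClCc1ccccc1Cn1cnc2c(Cl)nc(Cl)nc21` with 350 nM in a functional assay on HOP-92 cells (Homo sapiens) for cytotoxicity, read by sulforhodamine B assay, with a stated time of 48 h; on this read-out lower numbers stand for stronger inhibition of growth and higher numbers for weaker inhibition of growth
compound 2 `ClCc1ccccc1Cn1cnc2c(Cl)ncnc21` with 1480 nM in this assay
compound 3 `ClCc1ccc(Cn2cnc3c(Cl)nc(Cl)nc32)cc1` with "not determined" (no result reported) in this assay

Among the compounds with values here, compound 2 stands at the highest of the two numbers recorded in this assay; its nearest neighbour is compound 1, and the only measured step, a 4.2-fold higher number from compound 1 to compound 2 (0.63 log units; beyond the scatter), separates the two by a modest amount that lies beyond the scatter. That step exchanges a chloro group on the shared core for hydrogen.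

Compound 4 `Nc1nc(Cl)c2ncn(Cc3ccccc3CCl)c2n1` differs from compound 2 by amino in place of hydrogen on an aromatic carbon. Within the data shown here, this change touches the same carbon of the core that the single measured step altered, but the step from compound 1 to compound 2 compares chloro with hydrogen, not hydrogen with amino, so it only shows that this position is sensitive to substitution and gives no direction for an amino group. Among the measured compounds shown here, no other measured pair bears on the change, and compound 3 adds nothing because it has no number.

With so little to lean on, compound 4 is expected to return a number close to that of compound 2, with a 1.5-fold lower number from compound 2 to compound 4 (0.17 log units; within the scatter) as the estimated step and a wide allowance in either direction. The estimate for compound 4 in this assay is therefore 1000 nM, with a range from 250 nM to 4000 nM.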

Compound 4, concentration for 50% growth inhibition: 6460 nM
The estimate for compound 4 lay 6.5-fold (0.81 log units) below the measured number; the measured number lies above the stated range.
By their numbers in this assay, from the lowest: compound 1; then compound 2; then compound 4.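

Replacing hydrogen with amino on this carbon, between two ring nitrogen atoms, gives a 4.4-fold higher number from compound 2 to compound 4 (0.64 log units; beyond the scatter) in this assay and so weakens growth inhibition. The earlier step had shown only that removing chloro from this carbon raises the number; this one shows that adding a group here can raise it too, so the effect depends on which group is present rather than simply on whether the carbon is substituted. Set directly against chloro, the amino group gives an 18-fold higher number from compound 1 to compound 4 (1.27 log units; beyond the scatter) and this larger gap puts the three compounds in a clear order at this one carbon, with chloro giving the lowest number, hydrogen the middle one and amino the highest, each separated from the others by more than the scatter. Nothing available here explains why the amino group falls at the weak end of this order.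

The compounds shown leave open where a fluoro, methoxy or methylamino group on this carbon would fall in that order. They also leave open whether the order holds for the other arrangement of the chloromethyl group, seen in compound 3, which has no number in this assay.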